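Dropping the aryl group from a cytotoxicity-tested dihydropyrimidinone

This account rests on a few compounds, and the source may have more. Where it says the series, first, only, none or still open, it means among the compounds named here.

Of the compounds shown here, two have been measured so far in an ADME assay on Vero cells (Chlorocebus sabaeus) for cytotoxicity, read by sulforhodamine B assay, with a stated time of 3 days; on this read-out lower numbers stand for higher toxicity in this test and higher numbers for lower toxicity in this test. Compound 1, `CC1=C(C(=O)Nc2ccc(Cl)cc2)C(c2ccccc2O)C(C(=O)Nc2ccc(Cl)cc2)=C(C)N1`, gives 62 ug/mL in this assay. Compound 2, `COc1ccc(NC(=O)C2=C(C)NC(=O)NC2c2ccc(OC)cc2)cc1`, gives 158 ug/mL in this assay, the higher of the two numbers; its gap to compound 1 is wider than the usual scatter, so compound 2 is the less toxic of the pair on this read-out.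

The next compound, compound 3, `COc1ccc(NC(=O)C2=C(C)NC(=O)NC2)cc1`, differs from compound 2 in one place: hydrogen in place of 4-methoxyphenyl on a saturated ring carbon. Going by the values given here, no measured pair yet shows what such a change does in this assay, so the expectation rests on the two values alone. Since the change only removes a group and leaves a smaller molecule, a step of a 1.1-fold higher number from compound 2 to compound 3 (0.06 log units; within the scatter) of no more than the scatter is expected, in either direction. Compound 3 is therefore expected to give about 180 ug/mL in this assay, within a range from 80 ug/mL to 400 ug/mL.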

Compound 3, half-maximal cytotoxic concentration: 200 ug/mL
The estimate for compound 3 lay 1.1-fold (0.05 log units) below the measured number; measured number inside the range.
By their numbers in this assay, from the lowest: compound 1; then compounds 2 and 3 (each within the scatter of the next).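

Replacing the 4-methoxyphenyl group on this saturated ring carbon with hydrogen gives a 1.3-fold higher number from compound 2 to compound 3 (0.10 log units; within the scatter) in this assay. Going by these compounds alone, this is the first step that changes only one place, and it shows that the group can be lost entirely with no change beyond the scatter on this read-out, something the comparison of compound 1 and compound 2 could not show, as those two differ in more than one place. Nothing measured here gives a reason for this result.

Only this one replacement is shown at the position, so it stays open whether a methyl group, an amine or a carboxylic acid on the same carbon would also stay within the scatter. Going by these compounds, it is also open whether removing a group from this carbon would give a similar step on a different core, such as the core of compound 1.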